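The compounds below may be only part of what the source reports. "The series", "measured", "known", "first", "only" and "open" are said of these compounds alone.

Of the compounds shown here, three built on a shared core have been measured in an assay on Sf9 cells for inhibition of protein deacetylase HDAC6 (Homo sapiens), read by fluorescence, with a stated time of 40 min, tested at 100 nM; a higher number here means more inhibition at the concentration tested (going by the name of the read-out), a lower number less inhibition. Compound 1 `Cc1cccc(-c2nc(CNc3ccc(C(=O)NO)cc3)n(-c3ccccc3)n2)c1` gives 64.1%, compound 2 `COc1ccc(-c2nc(CNc3ccc(C(=O)NO)cc3)n(-c3ccccc3)n2)cc1` gives 77.6%, and compound 3 `O=C(NO)c1ccc(NCc2nc(-c3ccccc3)nn2-c2ccccc2Cl)cc1` gives 64.6%. Compound 2 thus stands highest of the three, beyond the scatter above both compound 3 and compound 1. Among the compounds with values here, the one single-point change measured so far, a number 13.5 percentage points higher from compound 1 to compound 2 (beyond the scatter), replaces 3-methylphenyl with 4-methoxyphenyl. Compound 4 `Cc1ccc(-c2nc(CNc3ccc(C(=O)NO)cc3)n(-c3ccccc3)n2)cc1` differs from compound 2 by methyl in place of methoxy on an aromatic carbon. The measured step bears on this only loosely. It changes two things at once, the group itself and where it sits on the ring. Compound 1 carries a methyl rather than a methoxy, and because compound 1 gives 64.1% a modest fall in this assay is expected when methoxy gives way to methyl, though it may not clear the scatter. Compound 4 is therefore estimated at 68%, with a likely range from 55% to 80%. The expected step is a number 9.6 percentage points lower from compound 2 to compound 4 (within the scatter).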

Compound 4, a percentage reported as inhibition, at one concentration (the size of the read-out at that concentration, not a potency): 62.2%
Beside the measured number, compound 4's estimate is 5.8 percentage points above it; measured number inside the range.
By their numbers in this assay, from the lowest: compounds 4, 1 and 3 (each within the scatter of the next); then compound 2.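

Holding the substituent at the same place on the ring, para to a large group, isolates the change of group in this assay: a number 15.4 percentage points lower from compound 2 to compound 4 (beyond the scatter), so exchanging methoxy for methyl matters on its own, which the earlier step, with group and place changing together, could not show. Moving the methyl alone gives a number 1.9 percentage points lower from compound 1 to compound 4 (within the scatter), so 3-methylphenyl and 4-methylphenyl cannot be told apart here. Among these compounds, the higher number of compound 2 therefore goes with the methoxy group, and the position of the methyl makes no visible difference.

No measurement here explains why methoxy and methyl differ. From the compounds shown here alone, it remains open whether an ethoxy group, a hydroxyl or an amine at this place would match compound 2, or fall back towards compound 4.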